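The source may report more compounds than this note shows. Statements on the series, on what has been measured and on what is new or still open speak of the compounds shown alone.

Compound 1 `O=C1C(Nc2cccc(Cl)c2)=CC(=O)c2c1nc1n2[C@H]2OC[C@@H](O)[C@H]2OC1` carries a (3-chlorophenyl)amino group on the shared core; in a functional assay on MGC-803 cells (Homo sapiens) for inhibition, read by sulforhodamine B assay (a higher number here means a weaker inhibitor, a lower number a stronger inhibitor), compound 1 gives 1530 nM. Compound 2 `O=C1C(NC2CCCCC2)=CC(=O)c2c1nc1n2[C@H]2OC[C@@H](O)[C@H]2OC1` bears a cyclohexylamino group in its place. In this assay compound 2 gives > 8000 nM, a limit of the assay rather than a number. Compound 3 `CCCN(CCC)C1=CC(=O)c2c(nc3n2[C@H]2OC[C@@H](O)[C@H]2OC3)C1=O` carries a dipropylamino group. In this assay compound 3 gives > 16000 nM, again only a limit and not a number (the limit of > 16000 nM in this assay, at which 1 of the 3 values shown sits). The step of an at least 10-fold higher number from compound 1 to compound 3 (1.01 log units; beyond the scatter) was large, while the step that the two limits leave unreadable from compound 2 to compound 3 cannot be read. Compound 4 `O=C1C(Nc2cccc(F)c2)=CC(=O)c2c1nc1n2[C@H]2OC[C@@H](O)[C@H]2OC1` differs from compound 3 by (3-fluorophenyl)amino in place of dipropylamino on a double-bonded ring carbon. Because an at least 10-fold higher number from compound 1 to compound 3 (1.01 log units; beyond the scatter) ran the other way, a large fall in the number is expected for compound 4. Compound 4 is therefore estimated at 2000 nM (from 700 nM to 6000 nM), a step of an at least 8.0-fold lower number from compound 3 to compound 4 (0.90 log units; beyond the scatter).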

Compound 4, half-maximal inhibitory concentration: 1470 nM
For compound 4 the middle estimate is 1.4-fold (0.13 log units) above the measured one; the measured number falls inside the stated range.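

Fluoro in place of chloro gives a 1.0-fold lower number from compound 1 to compound 4 (0.02 log units; within the scatter) and so makes no readable difference at the aromatic carbon. Compound 4 confirms the pattern of compound 1 with a second halogen, showing an at least 5.4-fold lower number from compound 2 to compound 4 (0.73 log units; beyond the scatter) against the cyclohexylamino group and an at least 10-fold lower number from compound 3 to compound 4 (1.03 log units; beyond the scatter) against the dipropylamino group. Both of these steps start from a limit of the assay and not from a number. From the compounds shown here alone, what a plain phenylamino, a 3-methoxyphenylamino or a benzylamino group would give on this double-bonded ring carbon remains open.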